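A few compounds are considered here, and "the series" means these few. Any claim that something is new, unique, unknown or untested is made for them only; others in the source may bear on it.

Measured so far:
- compound 1, `CCOC(=O)CO/N=C(\C)c1ccc(Sc2cc(F)cc(C3CCOCC3)c2)cc1`, giving 610 nM in a functional assay (blood) for inhibition, with Homo sapiens as the target; a higher number here means a weaker inhibitor, a lower number a stronger inhibitor
- compound 2, `COC1(c2csc(Sc3ccc4c(c3)OCC/C4=N\OCC#N)c2)CCOCC1`, giving 60 nM in this assay
- compound 3, `CO[C@]1(c2cnc(S(=O)(=O)c3ccc(/C(C)=N/O)cc3)s2)CCO[C@@H](C)C1`, giving 320 nM in this assay

Of these three, compound 1 has the highest number, so it is the weakest inhibitor of the set. Its gap to compound 3 lies within the usual scatter, so the two cannot be told apart; its gap to compound 2 lies beyond the scatter, and compound 2 is the stronger inhibitor of that pair.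

Compound 4, `C/C(=N\OC(=O)C(C)(C)C)c1ccc(Sc2cc(F)cc(C3CCOCC3)c2)cc1`, keeps the core of compound 1 and changes only the group on the oxygen attached to the double-bonded nitrogen: (tert-butyl)carbonyl in place of (ethoxycarbonyl)methyl on an oxygen. Within the data shown here, no pair of measured compounds shows this change, so its effect is unknown from the data at hand. Both groups are of the same size, with no ring and one double bond outside aromatic rings, so no step beyond the scatter is expected in this assay in either direction. Compound 4 is therefore expected to give about 550 nM, within a range of 220 nM to 1400 nM. That estimate means a step of a 1.1-fold lower number from compound 1 to compound 4 (0.04 log units; within the scatter), which is expected to sit inside the scatter.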

Compound 4, half-maximal inhibitory concentration: 40 nM
Compound 4: the middle estimate sits 14-fold (1.14 log units) above what was measured; the measured number lies below the stated range.
By their numbers in this assay, from the lowest: compounds 4 and 2 (each within the scatter of the next); then compounds 3 and 1 (each within the scatter of the next).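

In this assay, the group on the oxygen attached to the double-bonded nitrogen proves to be a sensitive place: (tert-butyl)carbonyl in place of (ethoxycarbonyl)methyl gives a 15-fold lower number from compound 1 to compound 4 (1.18 log units; beyond the scatter) with the rest of the molecule unchanged. The two groups have the same count of heavy atoms and the same count of double bonds, so those counts do not separate them, although the entering group carries one hydrogen-bond acceptor fewer and swaps an oxygen for a carbon. Nothing available explains why this single change has so large an effect.

It remains open whether the carbonyl or the tert-butyl part matters more, since the compounds shown include neither an acetyl group nor a plain tert-butyl group on this oxygen. They also leave open whether the same change would act alike on a different core, such as that of compound 2.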